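Bromo in Place of Ethoxy: Expecting Compound 3

The source may report more compounds than this note shows. Statements on the series, on what has been measured and on what is new or still open speak of the compounds shown alone.

Compound 1, `COc1ccc(C(=O)/C=C/c2ccc(Br)cc2)c2c1C=CC(C)(C)O2`, in a functional assay on HCT-116 cells (Homo sapiens) for antiproliferative activity, read by MTT assay, with a stated time of 24 h (on this read-out lower numbers stand for stronger inhibition and higher numbers for weaker inhibition), gives > 10000 nM, a limit of the assay and not a number.
Compound 2, `CCOc1cc(/C=C/C(=O)c2ccc(OC)c3c2OC(C)(C)C=C3)ccc1O`, in this assay gives > 10000 nM, likewise a limit.

For the measured compounds named here, compound 2 thus stands only at a limit, as does the one other value shown (the limit of > 10000 nM in this assay, at which 2 of the 2 values shown sit). Compound 3, `COc1ccc(C(=O)/C=C/c2ccc(O)c(Br)c2)c2c1C=CC(C)(C)O2`, differs from compound 2 in one place: bromo in place of ethoxy on an aromatic carbon, ortho to a hydroxy group and meta to a large group. Going by the values given here, with both measured compounds sitting at the limit, no step between measured compounds gives a direction, so no change beyond the scatter is expected in this assay. Compound 3 is therefore expected near 15000 nM, between 4000 nM and 60000 nM, a step that the limit leaves unreadable from compound 2 to compound 3 expected to stay within the scatter.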

Compound 3, half-maximal inhibitory concentration: > 10000 nM
Compound 3 gave a limit, no number; the forecaster's own chance of this, stated with the estimate: 70%; the middle value does not contradict the limit.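

No step among compound 1, compound 2 and compound 3 can be read in this assay, since each gives only a limit and not a number: the limit of > 10000 nM in this assay, at which 3 of the 3 values shown sit.

On these data alone, what stays open is whether bromo in place of ethoxy changes the activity at all, and how these three compounds would rank.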